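The source may report more compounds than this note shows. Statements on the series, on what has been measured and on what is new or still open speak of the compounds shown alone.

Compound 1 `CCOc1ccc(-c2cc(C(=O)O)nn2-c2ccccc2)cc1` gives 3260 nM in an assay for displacement of a labelled ligand from E3 ubiquitin-protein ligase Mdm2 (Homo sapiens), read by fluorescence polarization, with a stated time of 30 min; on this read-out higher numbers stand for weaker inhibition and lower numbers for stronger inhibition.
Compound 2 `CC(C)Oc1ccc(-c2cc(C(=O)O)nn2-c2ccccc2)cc1` gives 2290 nM in this assay.
Compound 3 `CC(C)COc1ccc(-c2cc(C(=O)O)nn2-c2ccccc2)cc1` gives 7420 nM in this assay.

Compound 2 stands at the low end of these three values: against compound 1 the step of a 1.4-fold lower number from compound 1 to compound 2 (0.15 log units; within the scatter) lies within the scatter, while against compound 3 the step of a 3.2-fold higher number from compound 2 to compound 3 (0.51 log units; beyond the scatter) lies beyond it. Compound 4 `CC(C)Oc1ccc(-c2cc(C(=O)O)nn2-c2ccc(C(C)C)cc2)cc1` differs from compound 2 by isopropyl in place of hydrogen on an aromatic carbon. Every measured step, including a 2.3-fold higher number from compound 1 to compound 3 (0.36 log units; beyond the scatter), alters the chain on the oxygen on an aromatic ring, so none of them bears on a change at this place. The series gives no guide, and the expected step of a 1.1-fold lower number from compound 2 to compound 4 (0.06 log units; within the scatter) is therefore kept close to no change beyond the scatter. Compound 4 is estimated at 2000 nM, within 600 nM to 7000 nM.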

Compound 4, inhibition constant: 2140 nM
Estimate against measurement, compound 4: 1.1-fold (0.03 log units) below; measured number inside the range.
By their numbers in this assay, from the lowest: compounds 4, 2 and 1 (each within the scatter of the next); then compound 3.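

Unlike the earlier steps, which all alter the chain on the oxygen, this change goes from phenyl to 4-isopropylphenyl. The result, a 1.1-fold lower number from compound 2 to compound 4 (0.03 log units; within the scatter), shows that isopropyl on this aromatic carbon, para to a large group, moves the number by no more than the scatter. No evidence at hand accounts for this outcome.

The compounds shown leave open whether an amine, a carboxylic acid or a longer chain on this carbon would do the same. They also leave open whether isopropyl here behaves alike with isobutyl on the oxygen.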